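Swapping Isopropyl for 3-Chloro-4-methoxyphenyl

The source may report more compounds than this note shows. Statements on the series, on what has been measured and on what is new or still open speak of the compounds shown alone.

For the measured compounds named here, in a functional assay on A2780 cells (Homo sapiens) for antiproliferative activity (a lower number here means a stronger inhibitor, a higher number a weaker inhibitor), compound 1 (`C#Cc1cccc(Nc2ncnn3ccc(COC[C@@H]4CNCCO4)c23)c1`) gives 3900 nM, the only number available so far. Compound 2 (`CC(C)Nc1ncnn2ccc(CN3CCC(N)CC3)c12`) has no place on this scale, as the entry for compound 2 reads "not determined" (no result reported). The next structure is compound 3 (`COc1ccc(Nc2ncnn3ccc(CN4CCC(N)CC4)c23)cc1Cl`). The change is 3-chloro-4-methoxyphenyl in place of isopropyl on a nitrogen on an aromatic ring.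

Going by the values given here, with no number for compound 2, there is no starting value from which to size this step in this assay, and no measured step exists to serve as a guide. Among the compounds with values here, the one anchor is compound 1 at 3900 nM, so the expectation is a result close to that value, with no gap beyond the usual scatter. Compound 3 is expected at about 2500 nM, with an estimated range of 600 nM to 10000 nM.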

Compound 3, half-maximal inhibitory concentration: > 5000 nM
Compound 3 was reported as a limit; the forecaster's own chance of this, stated with the estimate: 15%; at least 2.0-fold (0.30 log units) between middle value and limit.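

No step can be read from compound 2 to compound 3, since compound 2 has no number on this scale and compound 3 gives only a limit, > 5000 nM. As far as these compounds go, whether swapping isopropyl for 3-chloro-4-methoxyphenyl shifts antiproliferative activity, and how far, stays open.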